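Swapping a dichlorophenoxy arm for a methoxyphenyl sulfide

The source may hold more compounds than are shown below. What is called first, only, known or untested is meant among the compounds shown, and "the series" means these compounds.

The study centres on a shared core carrying a phenyl group and two amino groups, varied at one aromatic carbon. Compound 1 `Nc1cc(N)c2nc(-c3ccccc3)c(Oc3ccc(Cl)c(Cl)c3)nc2c1` is tested in a functional assay on NCI-H23 cells (Homo sapiens) for inhibition, read by sulforhodamine B assay, with a stated time of 48 h (a lower number here means a stronger inhibitor of growth, a higher number a weaker inhibitor of growth), where compound 1 gives 15500 nM. Among the three numbers known so far, compound 1 stands second highest. Compound 2 `CCOC(=O)[C@H](CCC(=O)O)NC(=O)c1ccc(Sc2nc3cc(N)cc(N)c3nc2-c2ccccc2)cc1` lies nearest: in this assay compound 2 gives 11700 nM, a gap from compound 1 that sits within the usual scatter. Compound 3 `CCOC(=O)[C@H](CCC(=O)O)NC(=O)c1ccc(CNc2nc3cc(N)cc(N)c3nc2-c2ccccc2)cc1` lies furthest: in this assay compound 3 gives 45700 nM, a gap from compound 1 that goes beyond the scatter.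

Compound 4 `COc1ccc(Sc2nc3cc(N)cc(N)c3nc2-c2ccccc2)cc1` has not yet been measured. It differs from compound 1 in one place: (4-methoxyphenyl)sulfanyl in place of 3,4-dichlorophenoxy on an aromatic carbon. Within the data shown here, no step between two measured compounds matches this change. A sulfanyl link to an aromatic ring can leave the number close to that of compound 1, as compound 2 shows with 11700 nM; in this assay compound 1 gives 15500 nM. On that basis compound 4 is expected to stay close to compound 1, and the step of a 1.3-fold lower number from compound 1 to compound 4 (0.11 log units; within the scatter) is estimated to lie within the scatter, with no clear direction. For compound 4 the expected value in this assay is 12000 nM, within a range from 5000 nM to 30000 nM.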

Compound 4, concentration for 50% growth inhibition: < 100000 nM
Compound 4: no number, only a limit (the forecaster's own chance of this, stated with the estimate: 10%); the middle value does not contradict the limit.
By their numbers in this assay, from the lowest: compounds 2 and 1 (each within the scatter of the next); then compound 3.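

In this assay compound 4 gives < 100000 nM, which is a limit and not a number. The step from compound 1 to compound 4 therefore cannot be read. The compounds shown leave open whether (4-methoxyphenyl)sulfanyl in place of 3,4-dichlorophenoxy changes the growth-inhibition number at all, and if so, in which direction.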